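The source may hold more compounds than are shown below. What is called first, only, known or untested is meant among the compounds shown, and "the series" means these compounds.

Measured compounds in a functional assay on MCF7 cells (Homo sapiens) for cytotoxicity, read by MTT assay, with a stated time of 72 h; on this read-out higher numbers stand for weaker inhibition and lower numbers for stronger inhibition:
- compound 1 `NS(=O)(=O)c1cc(-c2nnc(CN3CCC(Cc4ccccc4)CC3)o2)c(Cl)cc1SCc1ccccc1`: 170000 nM
- compound 2 `NC(=O)c1cn(Cc2nnc(-c3cc(S(N)(=O)=O)c(SCc4ccccc4)cc3Cl)o2)nn1`: 78000 nM
- compound 3 `COc1ccc(-c2cn(Cc3nnc(-c4cc(S(N)(=O)=O)c(SCc5ccccc5)cc4Cl)o3)nn2)cc1`: 1500000 nM

Compound 2 gives the lowest number of the three in this assay. Compound 1 sits nearest to it with a higher number, and compound 3 is furthest, with a much higher number still. Within the data shown here, the one step that can be read directly, a 19-fold higher number from compound 2 to compound 3 (1.28 log units; beyond the scatter), is large and runs toward weaker inhibition.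

Compound 4 `NS(=O)(=O)c1cc(-c2nnc(/C=C/c3ccccc3)o2)c(Cl)cc1SCc1ccccc1` is not yet measured. It differs from compound 2 in one place: 2-phenylethenyl in place of (4-carbamoyl-1H-1,2,3-triazol-1-yl)methyl on an aromatic carbon. Among the measured compounds shown here, no measured pair shows this exchange. The step from compound 2 to compound 3 touches the same region of the shared core, but it swaps only the substituent on the triazole and keeps the triazolylmethyl link, so it bears on compound 4 only loosely. Compounds 1 and 2 differ in the same place too, and their two values show a modest gap, with the carbamoyl-triazole at the lower number.

What can be said is that changes at this position of the core have so far moved the number upward from compound 2, once slightly and once strongly. The expectation for compound 4 is therefore a step toward a higher number, a 2.2-fold higher number from compound 2 to compound 4 (0.34 log units; beyond the scatter), with wide uncertainty. Compound 4 is estimated at 170000 nM, expected between 35000 nM and 800000 nM.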

Compound 4, half-maximal inhibitory concentration: 16000 nM
The estimate for compound 4 lay 11-fold (1.03 log units) above the measured number; measured number outside the range, below it.
By their numbers in this assay, from the lowest: compound 4; then compound 2; then compound 1; then compound 3.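

In this assay, among these compounds, 2-phenylethenyl in place of (4-carbamoyl-1H-1,2,3-triazol-1-yl)methyl gives a 4.9-fold lower number from compound 2 to compound 4 (0.69 log units; beyond the scatter) and so reverses the direction suggested by the earlier compounds: compound 1 and compound 3 both stand at higher numbers than compound 2, whereas this exchange on the aromatic carbon lowers the number. The carbamoyl-triazole is therefore not needed for the lower numbers seen so far, since the entering group, with one six-membered aromatic ring of carbon only and 0 hydrogen-bond donors and 0 hydrogen-bond acceptors, does better on this read-out. No supporting measurement accounts for the difference, and this single pair cannot separate the contributions of the ring, the double bond and the loss of the carbamoyl group.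

From the compounds shown here alone, it remains open whether the double bond matters, a question that a saturated 2-phenylethyl chain at the same position would address. Going by these compounds, the phenyl ring of the 2-phenylethenyl group also remains unexplored, so the effect of a carboxylic acid or an amine on that ring is unknown.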